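The compounds below may be only part of what the source reports. "The series", "measured", "known", "first", "only" and "open" are said of these compounds alone.

Measured so far in a functional assay (Homo sapiens) for inhibition of Nucleic Acid, tested at 100 uM; on this read-out higher numbers stand for more inhibition at the one concentration tested (going by the name of the read-out) and lower numbers for less inhibition:
- compound 1 `CSc1[nH]ccc2ncnc1-2` gives 4%
- compound 2 `OC[C@H]1OC(n2cnc3c(SCc4ccccc4)nccc32)[C@H](O)[C@@H]1O` gives 30%

Compound 2 is the higher of the two numbers in this assay, and compound 1 sits a good way below it, a gap that is beyond the usual scatter. The two compounds differ in more than one place, so no single step can be read from them; the values only show that compound 2 inhibits more at the one concentration tested.

The next compound, compound 3 `CCCCCCNc1nccc2c1ncn2C1O[C@H](CO)[C@@H](O)[C@H]1O`, has not been measured in this assay. It differs from compound 2 as follows: hexylamino in place of benzylsulfanyl on an aromatic carbon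

Among the compounds with values here, no step of this kind has been measured, so the expectation rests on compound 2 alone. The step from compound 2 to compound 3 is expected to be a modest loss, of a size that may lie within the scatter: a number 8 percentage points lower from compound 2 to compound 3 (within the scatter). Compound 3 is therefore expected to give about 22% in this assay, within a range from 2% to 48%.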

Compound 3, a percentage reported as inhibition, at one concentration (the size of the read-out at that concentration, not a potency): 8%
Beside the measured number, compound 3's estimate is 14 percentage points above it; low and high end bracket the measured number.
By their numbers in this assay, from the lowest: compounds 1 and 3 (each within the scatter of the next); then compound 2.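

In this assay, within the data shown here, the exchange of benzylsulfanyl for hexylamino on this aromatic carbon, next to the ring nitrogen, gives a number 22 percentage points lower from compound 2 to compound 3 (beyond the scatter) and is the first step that can be read. The position is therefore not indifferent to the group it carries, at least for these two groups at the one concentration tested. The step removes a sulfur atom and a six-membered aromatic ring of carbon only and brings in a nitrogen atom and a chain with no ring, and no measurement at hand accounts for the size of the step.

The compounds shown leave open whether the step follows the atom attached to the ring or the group at the end of it, a question that benzylamino or hexylsulfanyl on the same carbon would separate. Also open, as far as these compounds go, is how a shorter chain such as butylamino, or a plain amine at this position, would read in this assay on the same sugar-bearing core.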